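One ring stereocentre changed: compound 2 to compound 4

A few compounds are considered here, and "the series" means these few. Any claim that something is new, unique, unknown or untested is made for them only; others in the source may bear on it.

Measured in a physicochemical assay for lipophilicity; on this read-out higher numbers stand for higher lipophilicity and lower numbers for lower lipophilicity:
- compound 1 `CNC(=O)c1cc(C(=O)N[C@H]2[C@@H]3C[C@H](O)C[C@@H]32)n([C@@H](C)c2cccc(Cl)c2)n1`: 3.7
- compound 2 `CC[C@@H](c1ccccc1)n1nc(C(=O)NC)cc1C(=O)N[C@H]1[C@@H]2C[C@@H](O)C[C@@H]21`: 3.3
- compound 3 `CNC(=O)c1cc(C(=O)N[C@H]2CC[C@H](O)CC2)c([C@@H](C)c2cccc(OC)c2)o1`: 2.9

Compound 2 stands second highest of the three, with both neighbours beyond the scatter: compound 3 lower at 2.9 and compound 1 higher at 3.7. Compound 4 `CC[C@@H](c1ccccc1)n1nc(C(=O)NC)cc1C(=O)N[C@H]1[C@@H]2C[C@H](O)C[C@@H]21` is not yet measured. Against compound 2, the change is the two compounds have the same atoms and bonds and differ only in configuration as drawn: 1 of 5 stereo elements differ; a stereocentre at a saturated ring carbon is drawn R in compound 2 and S in compound 4: a stereocentre at a saturated ring carbon is drawn R in compound 2 and S in compound 4. No measured pair sizes such a change, so no step beyond the scatter is expected in this assay, and the reference stays compound 2 at 3.3. The estimated move is no change at the digits printed from compound 2 to compound 4 (within the scatter). Compound 4 is expected at 3.3, within an estimated range of 3 to 3.6.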

Compound 4, distribution coefficient: 3.6
Estimate against measurement, compound 4: 0.30 log units below; the measured number falls inside the stated range.
By their numbers in this assay, from the lowest: compound 3; then compounds 2, 4 and 1 (each within the scatter of the next, the first and the last beyond it).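

In this assay, the first pair to size a stereocentre at a saturated ring carbon gives a number 0.30 log units higher from compound 2 to compound 4 (within the scatter), and the comparison involves no other structural change: the fact that compounds 2 and 4 differ only in the configuration as drawn

The series also gains its first step at the group on the aromatic nitrogen, where 1-phenylpropyl in place of 1-(3-chlorophenyl)ethyl gives a number 0.10 log units lower from compound 1 to compound 4 (within the scatter).

As far as these compounds go, whether the stereocentre step holds with 1-(3-chlorophenyl)ethyl on the aromatic nitrogen remains open. Also open, from the compounds shown here alone, is how this assay responds to an amine or a carboxylic acid in place of 1-phenylpropyl on that nitrogen.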